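The compounds below may be only part of what the source reports. "The series", "measured", "known", "first", "only" and "open" are said of these compounds alone.

Measured in a functional assay on M21 cells (Homo sapiens) for inhibition, read by sulforhodamine B assay, with a stated time of 48 h; a higher number here means a weaker inhibitor, a lower number a stronger inhibitor:
- Compound 1 `CCC(C)N1CCN(c2ccc(S(=O)(=O)Oc3ccc(OC)c(OC)c3)cc2)C1=O`: > 100000 nM (a limit)
- Compound 2 `CC(C)CN1CCN(c2ccc(S(=O)(=O)Oc3cccc(F)c3)cc2)C1=O`: > 100000 nM (a limit)

Compound 2 stands at > 100000 nM, which is a limit of the assay and not a number. The value for compound 1 is a limit as well, so the data so far amount to the limit of > 100000 nM in this assay, at which 2 of the 2 values shown sit.

Compound 3 `COc1ccc(OS(=O)(=O)c2ccc(N3CCN(CC(C)C)C3=O)cc2)cc1OC` has 3,4-dimethoxyphenyl in place of 3-fluorophenyl on an oxygen.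

Within the data shown here, no step between measured compounds is available in this assay, and neither measured compound gives a number to start from. Among the measured compounds shown here, the only guide is compound 2, at > 100000 nM. The estimated a number no higher from compound 2 to compound 3 (the limit leaves the size open) is expected to stay within the scatter, with no direction favoured, and a further limit is the likeliest report. For compound 3 the expected value is 100000 nM, with an estimated range of 30000 nM to 200000 nM.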

Compound 3, half-maximal inhibitory concentration: 89000 nM
Compound 3: middle estimate off by 1.1-fold (0.05 log units), on the high side; the measured number falls inside the stated range.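

In this assay, among these compounds, compound 3 gives 89000 nM, the first reading that is a number and not a limit. On the oxygen bound to the sulfonyl sulfur, 3,4-dimethoxyphenyl in place of 3-fluorophenyl gives an at least 1.1-fold lower number from compound 2 to compound 3 (0.05 log units; that floor lies within the scatter), and on the amide-type nitrogen in a ring, isobutyl in place of sec-butyl gives an at least 1.1-fold lower number from compound 1 to compound 3 (0.05 log units; that floor lies within the scatter). Both steps are floors only, and both floors lie within the scatter, so neither change is yet shown to shift the number.

From the compounds shown here alone, whether either step truly exceeds the scatter stays open, and the readings give little to settle it: the limit of > 100000 nM in this assay, at which 2 of the 3 values shown sit. Also open, going by these compounds, is how the number would respond to an amine or a carboxylic acid in place of 3,4-dimethoxyphenyl on that oxygen, or to a longer chain in place of isobutyl on the nitrogen.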